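Oxime Analogue with Chloro Replacing Methoxy

The source may hold more compounds than are shown below. What is called first, only, known or untested is meant among the compounds shown, and "the series" means these compounds.

Compound 1 `COc1ccc(C(=O)CSc2nc3[nH]c(=O)n(C)c(=O)c3[nH]2)cc1` and compound 2 `Cn1c(=O)[nH]c2nc(SCC(=O)c3ccc(Cl)cc3)[nH]c2c1=O` share one core and differ only in the group on the aromatic ring, while compound 3 `COc1ccc(/C(CSc2nc3[nH]c(=O)n(C)c(=O)c3[nH]2)=N\O)cc1` and compound 4 `Cn1c(=O)[nH]c2nc(SC/C(=N/O)c3ccc(Cl)cc3)[nH]c2c1=O` carry another core; how the two cores differ is not broken down here. In a functional assay on PANC-1 cells (Homo sapiens) for inhibition, read by MTT assay, with a stated time of 48 h (a higher number here means a weaker inhibitor, a lower number a stronger inhibitor), compound 1 gives 5500 nM, and compound 2 gives 6100 nM. The step of a 1.1-fold higher number from compound 1 to compound 2 (0.04 log units; within the scatter) belongs to the change (chloro in place of methoxy on an aromatic carbon). The same change, (chloro in place of methoxy on an aromatic carbon), leads from compound 3 to compound 4, so it occurs twice among the compounds described. Compound 3 gives 1910 nM in this assay, the lowest of the three measured numbers, and its gap to compound 1 as well as to compound 2 lies beyond the scatter. Because a 1.1-fold higher number from compound 1 to compound 2 (0.04 log units; within the scatter) lies within the scatter, compound 4 is expected to stand close to compound 3, and the estimated step is a 1.1-fold higher number from compound 3 to compound 4 (0.04 log units; within the scatter). The estimate for compound 4 in this assay is therefore 2100 nM, with an expected range from 1000 nM to 4500 nM.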

Compound 4, half-maximal inhibitory concentration: 1700 nM
Beside the measured number, compound 4's estimate is 1.2-fold (0.09 log units) above it; the range from low to high includes it.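

In this assay, the change from 4-methoxyphenyl to 4-chlorophenyl gives a 1.1-fold lower number from compound 3 to compound 4 (0.05 log units; within the scatter), and the same change gave a matching result on the core of compound 1: the same change on two cores in this assay, a 1.1-fold higher number (0.04 log units; within the scatter) from compound 1 to compound 2 and a 1.1-fold lower number (0.05 log units; within the scatter) from compound 3 to compound 4, 1.2-fold (0.10 log units) apart, within the scatter of two such steps

On these two cores, then, chloro and methoxy in this place can be exchanged without a readable change in this assay, and the result on the core of compound 1 carries over to the core of compound 3. Among these compounds, this rests on only two pairs, however, and it shows neither that the exchange would stay as quiet on a further core or in a different assay, nor why the two groups read alike.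

The compounds shown leave open whether the ring tolerates groups of other kinds in this place, such as an amine, a carboxylic acid or a longer alkoxy chain. They also leave open whether chloro and methoxy would still read alike at another place on the same six-membered aromatic ring.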